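The source may hold more compounds than are shown below. What is called first, only, known or untested is meant among the compounds shown, and "the series" means these compounds.

In a functional assay on A-375 cells (Homo sapiens) for antiproliferative activity, read by CCK-8 assay, with a stated time of 72 h, tested at 2 uM (on this read-out lower numbers stand for a weaker effect and higher numbers for a stronger effect at the one concentration tested), compound 3 `Nc1ccccc1NC(=O)c1ccc(CSC(=S)N2CCN(c3ncccn3)CC2)cc1` gives 24%, the lowest of the three numbers shown, although its gap to compound 1 lies within the scatter. Compound 1 `Cc1ccc(N2CCN(C(=S)SCc3ccc(C(=O)Nc4ccccc4N)cc3)CC2)cc1` gives 25.8% and compound 2 `CN1CCN(C(=S)SCc2ccc(C(=O)Nc3ccccc3N)cc2)CC1` gives 36.6% in this assay. Compound 4 `Nc1ccccc1NC(=O)c1ccc(CSC(=S)N2CCN(c3cnccn3)CC2)cc1` has not yet been measured; it differs from compound 3 in one place: pyrazin-2-yl in place of pyrimidin-2-yl on an amine nitrogen in a ring, so the two have the same atoms joined differently. Within the data shown here, two measured steps touch the group on that ring nitrogen. One is a number 1.8 percentage points lower from compound 1 to compound 3 (within the scatter), a change from a six-membered carbon ring with a methyl to pyrimidin-2-yl that left the number where it was. The other is a number 12.6 percentage points lower from compound 2 to compound 3 (beyond the scatter), a drop when pyrimidin-2-yl took the place of methyl. Neither step exchanges one six-membered aromatic ring with two hetero atoms for another, and compound 1 and compound 3 show that two different aromatic groups on that nitrogen can sit within the scatter of each other. He therefore expects no step beyond the scatter, an estimated a number 2 percentage points higher from compound 3 to compound 4 (within the scatter) in this assay. For compound 4 in this assay the estimate is 26%, expected to fall between 14% and 38%.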

Compound 4, a percentage reported as inhibition, at one concentration (the size of the read-out at that concentration, not a potency): 29.1%
For compound 4 the middle estimate is 3.1 percentage points below the measured one; measured number inside the range.
By their numbers in this assay, from the lowest: compounds 3, 1, 4 and 2 (each within the scatter of the next, the first and the last beyond it).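

In this assay, among these compounds, the exchange of pyrimidin-2-yl for pyrazin-2-yl on the amine nitrogen in a ring is the first step at this position that keeps the same atoms and only joins them differently, and a number 5.1 percentage points higher from compound 3 to compound 4 (within the scatter) shows that the rearrangement does not separate the two groups in this read-out. The 4-methylphenyl group also stays level with the new group, with a number 3.3 percentage points higher from compound 1 to compound 4 (within the scatter) as the printed step, so compounds 1, 3 and 4 all lie within the scatter of one another despite carrying three different aromatic groups on that nitrogen. The methyl group now looks less clearly set apart: a number 12.6 percentage points lower from compound 2 to compound 3 (beyond the scatter) lies beyond the scatter, whereas a number 7.5 percentage points lower from compound 2 to compound 4 (within the scatter) does not, so the earlier drop from methyl to an aromatic group does not hold for both groups with two ring nitrogens, even though those two groups cannot themselves be told apart here.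

The compounds shown leave open how an ethyl group, a longer alkyl chain, or a pyridin-2-yl ring with a single ring nitrogen would behave on this nitrogen. Nothing available here accounts for any of these numbers.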